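The compounds below may be only part of what the source reports. "The series", "measured", "known", "first", "only" and "open" are said of these compounds alone.

In a functional assay on HepG2 cells (Homo sapiens) for antiproliferative activity, read by MTT assay, with a stated time of 48 h (a higher number here means a weaker inhibitor, a lower number a stronger inhibitor), compound 3 (`O=c1cc(-c2ccccc2)oc2cc(OCc3ccccc3)c(OCCCN3CCCC3)c(O)c12`) gives 4200 nM and sits within the scatter of compound 2 (`CCN(CC)CCCCOc1c(OC)cc2oc(-c3ccccc3)cc(=O)c2c1O`), which gives 7100 nM in the same test. Compound 1 (`COc1cc2oc(-c3ccccc3)cc(=O)c2c(O)c1OCCCCN1CCN(C)CC1`) gives 36700 nM and stands clearly higher than both. Compound 4 (`COc1cc2oc(-c3ccccc3)cc(=O)c2c(O)c1OCCCN1CCCC1`) keeps the amine end of compound 3 and changes one group: hydrogen in place of phenyl on a saturated chain carbon bound to an oxygen on an aromatic ring and the same difference reads as benzyloxy to methoxy.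

Going by the values given here, no measured step covers this change. The only one (a 5.2-fold lower number from compound 1 to compound 2 (0.71 log units; beyond the scatter)) replaces 4-methylpiperazin-1-yl with diethylamino at the amine end, so it bears only indirectly, showing that the methoxy compounds can move beyond the scatter with the amine end alone. Both compounds with methoxy have higher numbers than compound 3, although they also differ from it at the amine end: compound 2 gives 7100 nM and compound 1 gives 36700 nM in this assay as the nearest guides. A modest step toward a higher number is therefore expected (a 2.1-fold higher number from compound 3 to compound 4 (0.33 log units; beyond the scatter)), with little certainty about its size. For compound 4 the estimated value is 9000 nM in this assay, with an expected range from 3000 nM to 25000 nM in that test.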

Compound 4, half-maximal inhibitory concentration: 4300 nM
The estimate for compound 4 lay 2.1-fold (0.32 log units) above the measured number; the measured number falls inside the stated range.
By their numbers in this assay, from the lowest: compounds 3, 4 and 2 (each within the scatter of the next); then compound 1.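

In this assay, going by these compounds alone, the exchange of benzyloxy for methoxy is the first direct reading at this position, and a 1.0-fold higher number from compound 3 to compound 4 (0.01 log units; within the scatter) places the pair within the scatter, so with the pyrrolidin-1-yl end held constant, removing the phenyl and its six carbons leaves no detectable mark on the number. The amine end, by contrast, still separates the methoxy compounds: an 8.5-fold lower number from compound 1 to compound 4 (0.93 log units; beyond the scatter) with pyrrolidin-1-yl in place of (4-methylpiperazin-1-yl)methyl, while a 1.7-fold lower number from compound 2 to compound 4 (0.22 log units; within the scatter) with pyrrolidin-1-yl in place of (diethylamino)methyl. Among these three methoxy compounds, only compound 1 stands apart, and compounds 2 and 4 remain within the scatter of each other. No measurement shown here accounts for either reading.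

Going by these compounds, it remains open whether this result holds at other amine ends, such as diethylamino or 4-methylpiperazin-1-yl carried together with benzyloxy, since the comparison rests on a single pair. On these data alone, it is also open whether a free hydroxyl, an ethoxy group or a 4-chlorobenzyloxy group at this position would stay within the scatter of these two compounds.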